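This account rests on a few compounds, and the source may have more. Where it says the series, first, only, none or still open, it means among the compounds named here.

The measured compounds and their solubilities:

compound 1, `O=C(CCCCCNc1c(NCc2ccccc2)c(=O)c1=O)NO`: 75000000 nM
compound 2, `CC[C@H](Nc1c(NCCCCCC(=O)NO)c(=O)c1=O)c1ccccc1`: 75000000 nM

Both were tested in a physicochemical assay for solubility, read by HPLC, in phosphate buffer, with a stated time of 24 h, at pH 7.4, tested at 100 uM; a higher number here means a more soluble compound, a lower number a less soluble compound. Compound 1 gives 75000000 nM and stands level with compound 2 at the digits shown; the one measured step, no change at the digits printed from compound 1 to compound 2 (within the scatter), is an ethyl in place of hydrogen on a saturated chain carbon bound to an aromatic carbon and a nitrogen on an aromatic ring, and it leaves the number unchanged within the scatter.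

Compound 3, `Cc1cccc(Nc2c(NCCCCCC(=O)NO)c(=O)c2=O)c1`, is not yet measured in this assay. It differs from compound 1 by 3-methylphenyl in place of benzyl on a nitrogen on an aromatic ring. The measured step touches the same benzylamino arm, though it adds to the chain carbon rather than removing it, so it bears on the question only loosely; it shows no movement. With nothing in the data pointing either way, the expected step of a 1.4-fold lower number from compound 1 to compound 3 (0.13 log units; within the scatter) is small, with somewhat more room on the lower side. Compound 3 is therefore estimated at 55000000 nM, with a range from 25000000 nM to 100000000 nM.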

Compound 3, solubility: 79000000 nM
Estimate against measurement, compound 3: 1.4-fold (0.16 log units) below; the range from low to high includes it.
By their numbers in this assay, from the lowest: compounds 1, 2 and 3 (each within the scatter of the next).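

In this assay, the step to compound 3 is a 1.1-fold higher number from compound 1 to compound 3 (0.02 log units; within the scatter), so replacing benzyl with 3-methylphenyl on a nitrogen on an aromatic ring leaves the two values within the scatter of each other. The earlier step kept the saturated carbon of the benzylamino arm and added ethyl to it, whereas this change replaces that arm with (3-methylphenyl)amino, which has its aromatic ring bound directly to the nitrogen and carries a methyl on the ring; the count of heavy atoms stays the same, and so does the absence of hydrogen-bond donors, acceptors and net charge in the group. The result therefore extends what is seen at this position from a substituent on the chain carbon to a rearrangement of the same atoms, although nothing available explains why the values stand level.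

These compounds leave open whether the same holds when the group on this nitrogen carries an amine or a carboxylic acid, since every arm shown is built from carbon alone. They also leave open how a pyridine ring or a longer chain in this arm would read in this assay, and whether the hydroxamic acid chain on the other side of the core tolerates change equally.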